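Ester versus ketone at the carbonyl in a furyl series

This account rests on a few compounds, and the source may have more. Where it says the series, first, only, none or still open, it means among the compounds named here.

Measured so far: compound 1 `CC1=C(C(=O)OC(C)(C)C)C(c2ccoc2)NC(=O)N1`, 4440 nM; compound 2 `CC1=C(C(=O)CC(C)C)C(c2ccoc2)NC(=O)N1`, 1010 nM, both in an assay on membranes from HEK293 cells for displacement of a labelled ligand from adenosine receptor A2b (Homo sapiens), read by scintillation counting, with a stated time of 30 min; a lower number here means a stronger inhibitor, a higher number a weaker inhibitor.

Compound 2 stands lowest of the two numbers in this assay; its nearest neighbour is compound 1, reached by a 4.4-fold lower number from compound 1 to compound 2 (0.64 log units; beyond the scatter). Compound 3 `CCC(C)OC(=O)C1=C(C)NC(=O)NC1c1ccoc1` differs from compound 2 by sec-butoxy in place of isobutyl on a carbonyl carbon. Among the compounds with values here, this largely reverses the one measured step, which swapped an alkoxy group for an alkyl group on that carbonyl carbon; the same change in the opposite direction is therefore expected to raise the number by a comparable, modest amount. For compound 3 the expected step is a 3.2-fold higher number from compound 2 to compound 3 (0.50 log units; beyond the scatter), giving an estimate of 3200 nM, within 1200 nM to 8500 nM.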

Compound 3, inhibition constant: 201 nM
Compound 3: middle estimate off by 16-fold (1.20 log units), on the high side; measured number below the stated range.
By their numbers in this assay, from the lowest: compound 3; then compound 2; then compound 1.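

In this assay an alkoxy group on this carbonyl carbon is not in itself worse than isobutyl: sec-butoxy gives a 5.0-fold lower number from compound 2 to compound 3 (0.70 log units; beyond the scatter), against the direction set by compound 1. On the oxygen, sec-butyl in place of tert-butyl gives a 22-fold lower number from compound 1 to compound 3 (1.34 log units; beyond the scatter) with nothing else altered. Ester and ketone therefore cannot be ranked apart from the alkyl group on that oxygen.

Going by these compounds, whether a longer chain such as n-butyl, or a cyclopentyl group, on that oxygen lowers the number further stays open. Nothing available explains the gap between the sec-butyl and tert-butyl esters.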